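Swapping fluorine for chlorine on a bis-arylidene cyclohexanone

This account rests on a few compounds, and the source may have more. Where it says the series, first, only, none or still open, it means among the compounds named here.

This account follows two measured compounds and one yet to be tested in a functional assay on MOLT-4 cells (Homo sapiens) for cytotoxicity, with a stated time of 72 h; a lower number here means a stronger inhibitor, a higher number a weaker inhibitor. Compound 1 `CN(C)c1ccc(/C=C2\CCC/C(=C\c3ccccc3[N+](=O)[O-])C2=O)cc1` gives 122000 nM in this assay. Going by the values given here, compound 2 `O=C1/C(=C/c2ccc(F)cc2)CCC/C1=C\c1ccccc1[N+](=O)[O-]` gives 1870 nM in this assay, the lowest of the two numbers; the only step among the measured pair, a 65-fold lower number from compound 1 to compound 2 (1.81 log units; beyond the scatter), is large and beyond the scatter. Compound 3 `O=C1/C(=C/c2ccc(Cl)cc2)CCC/C1=C\c1ccccc1[N+](=O)[O-]` differs from compound 2 by chloro in place of fluoro on an aromatic carbon. Among the compounds with values here, no measured step covers this exchange of one halogen for another, so the one recorded step, from a dimethylamino group to fluoro, bears on it only loosely: it shows that the substituent on this ring can move the number by a large margin, but says nothing about fluoro against chloro. For such a change a step within the scatter in this assay, in no settled direction, is expected, amounting to a 1.2-fold lower number from compound 2 to compound 3 (0.10 log units; within the scatter). Compound 3 is therefore estimated at 1500 nM in this assay, with a range from 500 nM to 5000 nM.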

Compound 3, half-maximal inhibitory concentration: 3860 nM
Beside the measured number, compound 3's estimate is 2.6-fold (0.41 log units) below it; the measured number falls inside the stated range.
By their numbers in this assay, from the lowest: compound 2; then compound 3; then compound 1.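

In this assay the exchange of one halogen for the other at this position is not neutral: moving from 4-fluorophenyl to 4-chlorophenyl gives a modest change beyond the scatter (a 2.1-fold higher number from compound 2 to compound 3 (0.31 log units; beyond the scatter)), which leaves compound 2 with the lowest number of the three. The large distance from the dimethylamino compound is also not confined to fluoro, since chloro on the same aromatic carbon likewise gives a large step (a 32-fold lower number from compound 1 to compound 3 (1.50 log units; beyond the scatter)). Nothing available here accounts for the difference between the two halogens.

As far as these compounds go, the three compounds cover only dimethylamino, fluoro and chloro on this ring, so it remains open whether bromo, methoxy, trifluoromethyl or a plain unsubstituted phenyl would follow the order seen here. From the compounds shown here alone, it is equally open whether the preference for fluoro over chloro would persist if the nitro group shared by all three compounds gave way to a nitrile or a carboxylic acid, or whether it holds on cells other than those of this single assay.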